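Dichlorophenyl urea in a diaryl urea series

The source may hold more compounds than are shown below. What is called first, only, known or untested is meant among the compounds shown, and "the series" means these compounds.

compound 1 `O=C(Nc1ccc(Nc2ncnc3c2OCCN3)cc1)Nc1ccc(Cl)c(C(F)(F)F)c1`: 188 nM
compound 2 `COc1ccc(NC(=O)Nc2ccc(Nc3ncnc4c3OCCN4)cc2)cc1`: 824 nM

In an assay on isolated protein for inhibition of proto-oncogene tyrosine-protein kinase receptor Ret variant V804M (Homo sapiens), read by 33P incorporation, with stated times of 15 min and 40 min (on this read-out lower numbers stand for stronger inhibition and higher numbers for weaker inhibition), compound 1 gives 188 nM and compound 2 gives 824 nM. Compound 2 has the higher of the two numbers, and its gap to compound 1 lies beyond the scatter. Compound 3 `O=C(Nc1ccc(Nc2ncnc3c2OCCN3)cc1)Nc1cc(Cl)cc(Cl)c1` arises from compound 2 by 3,5-dichlorophenyl in place of 4-methoxyphenyl on an amide-type nitrogen. Going by the values given here, no measured pair shows this exact change, so the expectation rests on compound 1, which also carries chlorine on this ring and gives 188 nM. A lowering beyond the scatter is expected, as a 2.7-fold lower number from compound 2 to compound 3 (0.44 log units; beyond the scatter). Compound 3 is estimated at 300 nM, within 120 nM to 750 nM.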

Compound 3, half-maximal inhibitory concentration: 1300 nM
Compound 3: the middle estimate sits 4.3-fold (0.64 log units) below what was measured; the whole stated range lies below it.
By their numbers in this assay, from the lowest: compound 1; then compounds 2 and 3 (each within the scatter of the next).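

In this assay the change to 3,5-dichlorophenyl on an amide-type nitrogen gives a 1.6-fold higher number from compound 2 to compound 3 (0.20 log units; within the scatter), so it does not separate these two compounds. Chlorine on this ring thus does not by itself go with a lower number: compound 1 gives 188 nM and compound 3 gives 1300 nM in the same assay. Nothing at hand explains this result.

On these data alone, what remains open is whether the trifluoromethyl group of compound 1 accounts for its lower number. As far as these compounds go, how a ring carrying a nitrile or an amine would read also stays open.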